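A few compounds are considered here, and "the series" means these few. Any claim that something is new, unique, unknown or untested is made for them only; others in the source may bear on it.

Measured in a functional assay on SGC-7901 cells (Homo sapiens) for cytotoxicity, read by MTT assay, with a stated time of 48 h; on this read-out lower numbers stand for stronger inhibition and higher numbers for weaker inhibition:
- compound 1 `CC(=O)N1N=C(C)CC1c1ccccc1OCc1ccc(Cl)nc1`: "not active" (no number reported)
- compound 2 `O=c1cc(-c2ccccc2)oc2cc(OCc3ccc(Cl)nc3)cc(O)c12`: "not active" (no number reported)
- compound 3 `COc1ccc(-c2cc(=O)c3ccc(OCc4ccc(Cl)nc4)cc3o2)cc1`: 35.2 ug/mL

Compound 2 reads "not active" (no number reported), so it has no single number. Among the compounds with values here, compound 1 is the one other entry without a number, and neither can be set on a scale against the single measured value.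

Compound 4 `O=c1cc(-c2ccc(OCc3ccc(Cl)nc3)cc2)oc2cc(OCc3ccc(Cl)nc3)cc(O)c12` remains unmeasured. The change is (6-chloropyridin-3-yl)methoxy in place of hydrogen on an aromatic carbon, with (6-chloropyridin-3-yl)methoxy in place of hydrogen on an aromatic carbon.

With no number for compound 2, the size of this step in this assay cannot be read from the data. A modest move toward stronger inhibition is expected, though another reading without a number remains quite possible. Within the data shown here, the only numerical anchor is compound 3 at 35.2 ug/mL, so any value should fall near that level. Compound 4 is estimated at 40 ug/mL, with an expected range of 15 ug/mL to 100 ug/mL.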

Compound 4, half-maximal inhibitory concentration: 22.3 ug/mL
Compound 4: the middle estimate sits 1.8-fold (0.25 log units) above what was measured; low and high end bracket the measured number.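

In this assay, within the data shown here, compound 4 gives 22.3 ug/mL while compound 2 reads "not active" (no number reported) so no step between compound 2 and compound 4 can be read. Going by these compounds, what the added (6-chloropyridin-3-yl)methoxy contributes to cytotoxicity stays open. No measured evidence bears on this result.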